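Swapping a benzyl arm for a direct tolyl ring

This account rests on a few compounds, and the source may have more. Where it says the series, first, only, none or still open, it means among the compounds named here.

Compound 1 `Nc1cccc(-c2cn3nc(Cc4ccccc4)sc3n2)c1` gives 37000 nM in a functional assay on CCRF-CEM cells (Homo sapiens) for inhibition, read by cell counting, with a stated time of 3 days (a higher number here means a weaker inhibitor, a lower number a stronger inhibitor), the lower of the two plain numbers in hand. Compound 3 `COc1cccc(Cc2nn3cc(-c4cccc(N)c4)nc3s2)c1` gives 40000 nM, and a 1.1-fold higher number from compound 1 to compound 3 (0.03 log units; within the scatter). Compound 2 `COc1ccc(Cc2nn3cc(-c4cccc(N)c4)nc3s2)cc1` returns only a limit of the assay, >= 250000 nM. From that limit, an at least 6.2-fold lower number from compound 2 to compound 3 (0.79 log units; beyond the scatter), and an at least 6.7-fold higher number from compound 1 to compound 2 (0.82 log units; beyond the scatter); the limit itself is the limit of >= 250000 nM in this assay, at which 1 of the 3 values shown sits.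

Compound 4 `Cc1ccc(-c2nn3cc(-c4cccc(N)c4)nc3s2)cc1` differs from compound 1 by 4-methylphenyl in place of benzyl on an aromatic carbon. The measured steps all add a methoxy to the benzyl ring and leave the benzyl itself in place, so none of them covers removing the linking carbon and attaching a 4-methylphenyl directly. Among the compounds with values here, the only guidance is that a change on the benzyl ring was either neutral or harmful, never helpful. A weaker number is therefore expected for compound 4, though with wide uncertainty, and the estimated step is a 1.9-fold higher number from compound 1 to compound 4 (0.28 log units; within the scatter). The estimate for compound 4 is 70000 nM, expected to lie between 15000 nM and 250000 nM.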

Compound 4, half-maximal inhibitory concentration: 5900 nM
Compound 4: the middle estimate sits 12-fold (1.07 log units) above what was measured; measured number outside the range, below it.
By their numbers in this assay, from the lowest: compound 4; then compounds 1 and 3 (each within the scatter of the next). At a limit, above all of these: compound 2.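

Up to now, every change at this position kept the benzyl arm and only added a methoxy to its ring, and none of those steps took this assay beyond the scatter towards a lower number than compound 1. Replacing benzyl with 4-methylphenyl, a group with the same 7 heavy atoms that sits directly on the five-membered aromatic ring, gives a 6.3-fold lower number from compound 1 to compound 4 (0.80 log units; beyond the scatter), so rearranging these atoms alone can make a clear difference. Nothing in the data shown explains this gain.

This single swap removes the linking carbon and brings in a methyl together, so the compounds shown cannot tell how much each contributes. From the compounds shown here alone, a plain phenyl at this position would separate the two, and a methoxy or a chlorine on the directly attached ring remains open as well.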